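The source may hold more compounds than are shown below. What is called first, only, known or untested is meant among the compounds shown, and "the series" means these compounds.

Measured so far:
Compound 1, `CC(Sc1nnc(-c2ccncc2)s1)C(=O)Nc1ccc(Cl)cc1Cl`: > 50000 nM, a limit
Compound 2, `CC(Sc1nnc(-c2ccncc2)s1)C(=O)Nc1ccccc1Cl`: > 50000 nM, a limit
Compound 3, `CC(Sc1nnc(-c2ccncc2)s1)C(=O)Nc1c(Cl)cccc1Cl`: > 50000 nM, a limit

All three share one core and differ only in the chlorines on the ring that sits on the amide nitrogen. In an ADME assay on HepG2 cells (Homo sapiens) for cytotoxicity, with a stated time of 3 days (on this read-out lower numbers stand for higher toxicity in this test and higher numbers for lower toxicity in this test), compound 3 gives only a limit, > 50000 nM, and not a number. The same holds for the other two: the limit of > 50000 nM in this assay, at which 3 of the 3 values shown sit. The steps between them therefore cannot be sized: a step that the two limits leave unreadable from compound 1 to compound 2, a step that the two limits leave unreadable from compound 1 to compound 3 and a step that the two limits leave unreadable from compound 2 to compound 3 all remain unreadable, and none of them shows a difference in toxicity.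

Compound 4, `CC(Sc1nnc(-c2ccncc2)s1)C(=O)Nc1ccc(Cl)cc1`, has not yet been measured in this assay. It differs from compound 3 in one place: 4-chlorophenyl in place of 2,6-dichlorophenyl on an amide-type nitrogen. Every measured step that bears on this change, each a move of a chlorine on that ring, sat at the limit on both sides, so no step beyond the scatter is expected here either; the number is expected to stay at the limit, a step that the limit leaves unreadable from compound 3 to compound 4.

Compound 4 is therefore estimated at 70000 nM in this assay, within a range from 30000 nM to 200000 nM, most likely reported again as a limit.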

Compound 4, half-maximal cytotoxic concentration: > 50000 nM
Compound 4 gave a limit, no number; the forecaster's own chance of this, stated with the estimate: 85%; the middle value is on the limit's open side.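

In this assay compound 4 gives the limit > 50000 nM and not a number. No step between compound 4 and compound 1, compound 2 or compound 3 can be read, and the reason is shared: the limit of > 50000 nM in this assay, at which 4 of the 4 values shown sit. The compounds shown leave open whether any change of the chlorines on that ring alters toxicity in this assay at all.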